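A Methyl Added to the Terminal Phenyl of the Urea

This account rests on a few compounds, and the source may have more. Where it says the series, first, only, none or still open, it means among the compounds named here.

Three compounds share a core in which a quinazoline-type amine carries a benzyl group bearing a diaryl urea. Compound 1 `COc1ccc(NC(=O)Nc2cccc(CNc3ncnc4ccccc34)c2)cc1` gives 29300 nM in a functional assay on A549 cells (Homo sapiens) for antiproliferative activity, read by MTT assay; on this read-out lower numbers stand for stronger inhibition and higher numbers for weaker inhibition. Compound 2 `O=C(Nc1cccc(Cl)c1)Nc1cccc(CNc2ncnc3ccccc23)c1` reaches only the limit of the assay, > 50000 nM in this assay. Compound 3 `COc1cc2ncnc(NCc3cccc(NC(=O)Nc4ccccc4)c3)c2cc1OC` gives 17100 nM in this assay, the lowest of the two numbers shown, and its nearest neighbour is compound 1, whose number is higher by a margin that lies within the scatter.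

Compound 4 `COc1cc2ncnc(NCc3cccc(NC(=O)Nc4cccc(C)c4)c3)c2cc1OC` differs from compound 3 by one change: methyl in place of hydrogen on an aromatic carbon, so that phenylcarbamoyl becomes (3-methylphenyl)carbamoyl. Among the measured compounds shown here, the only measured step that touches the same terminal ring is an at least 1.7-fold higher number from compound 1 to compound 2 (0.23 log units; that floor lies within the scatter), which ends at a limit of > 50000 nM in this assay, at which 1 of the 3 values shown sits, and so sets no firm size. For the measured compounds named here, a single methyl is a smaller change than that exchange, and no measured step shows a gain from decorating this ring, so a shift within the scatter, in either direction, is the most that is expected.

Compound 4 is therefore expected at 16000 nM, between 6000 nM and 45000 nM, a step of a 1.1-fold lower number from compound 3 to compound 4 (0.03 log units; within the scatter) that is expected to stay within the scatter.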

Compound 4, half-maximal inhibitory concentration: 27100 nM
The estimate for compound 4 lay 1.7-fold (0.23 log units) below the measured number; measured number inside the range.
By their numbers in this assay, from the lowest: compounds 3, 4 and 1 (each within the scatter of the next). At a limit, above all of these: compound 2.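

In this assay, methyl in place of hydrogen on the terminal phenyl of the urea gives a 1.6-fold higher number from compound 3 to compound 4 (0.20 log units; within the scatter). Among the compounds shown here, this is the first step on that ring with a number at both ends, and it shows that a methyl placed meta to a large group, turning phenyl into 3-methylphenyl, leaves the read-out within the scatter on this core. The earlier step on the same ring gave no such size, since compound 2 stands at a limit, > 50000 nM. Nothing at hand gives a cause for the new step.

On these data alone, whether another group on this ring, such as an amine, a carboxylic acid or a longer chain in place of the methyl, would move the number beyond the scatter remains open. Also open is whether the same methyl would give a similarly small step on the core of compound 1, since the compounds shown test this change only once, on the core of compound 3.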